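The source may report more compounds than this note shows. Statements on the series, on what has been measured and on what is new or still open speak of the compounds shown alone.

Working notes on the series, cytotoxicity arm.

The series is assessed in an ADME assay on HCT-116 cells (Homo sapiens) for cytotoxicity, read by CellTiter-Glo, with a stated time of 72 h; a lower number here means a stronger inhibitor, a higher number a weaker inhibitor. Compound 1 `Cc1cc(C)c(S(=O)(=O)N2CCC(C3OCC(C)CO3)CC2)c(C)c1` returns only an assay limit in this assay, > 5000 nM, and not a number. Compound 2 `CC1CCN(C2CCN(S(=O)(=O)c3ccc(F)cc3F)CC2)CC1` also returns a limit in this assay, > 5000 nM. Compound 3 `Cc1ccc(-c2cccc(S(=O)(=O)N3CCC(N4CCC(C)CC4)CC3)c2)cc1` likewise returns a limit in this assay, > 5000 nM. So compound 1 stands nowhere distinguishable from the other two: all three sit at the limit of > 5000 nM in this assay, at which 3 of the 3 values shown sit, and no ordering among them can be read from the numbers shown.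

Compound 4 `Cc1cc(C)c(S(=O)(=O)N2CCC(N3CCC(O)CC3)CC2)c(C)c1` is the next to be measured in this assay. It differs from compound 1 in one place, (a group of 7 heavy atoms (5 carbon, 1 nitrogen, 1 oxygen; one six-membered non-aromatic ring with 1 hetero atom) in place of a group of 7 heavy atoms (5 carbon, 2 oxygen; one six-membered non-aromatic ring with 2 hetero atoms), on a saturated ring carbon).

For the measured compounds named here, no step between measured compounds exists from which to judge this change, and every value shown is a limit. The expectation for the step from compound 1 to compound 4 is therefore no movement beyond the scatter, a step that the limit leaves unreadable from compound 1 to compound 4, with compound 4 most likely reporting a limit again. Compound 4 is estimated at 10000 nM, within 5000 nM to 50000 nM, in this assay.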

Compound 4, half-maximal inhibitory concentration: > 5000 nM
Compound 4: a limit, no number; the forecaster's own chance of this, stated with the estimate: 85%; the middle value lies beyond the limit too.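

The step between compound 1 and compound 4 cannot be read, as both report only a limit in this assay: the limit of > 5000 nM in this assay, at which 4 of the 4 values shown sit.

The compounds shown leave open whether any member of the series has a measurable cytotoxicity value, and thus how the 4-hydroxypiperidin-1-yl group compares with the group it replaces.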